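Moving the Carboxylic Acid on the Fluorophenyl Group

The source may hold more compounds than are shown below. What is called first, only, known or untested is meant among the compounds shown, and "the series" means these compounds.

Compound 1 `CC#CCn1c(N2CCC[C@@H](N)C2)cc(=O)n(Cc2cccc(C(=O)O)c2Br)c1=O` — "not determined" (no result reported)
Compound 2 `CC#CCn1c(N2CCC[C@@H](N)C2)cc(=O)n(Cc2ccc(F)c(C(=O)OC)c2)c1=O` — > 100 nM
Compound 3 `CC#CCn1c(N2CCC[C@@H](N)C2)cc(=O)n(Cc2ccc(F)c(C(=O)O)c2)c1=O` — > 100 nM

In an assay on isolated protein for inhibition of Dipeptidyl peptidase 9 (Homo sapiens), read by fluorescence, with stated times of 15 min and 20 min (a lower number here means a stronger inhibitor, a higher number a weaker inhibitor), compound 3 gives > 100 nM, which is a limit of the assay and not a number. Compound 2 likewise gives > 100 nM, again a limit. For compound 1 no result is reported in this assay: "not determined" (no result reported). For the measured compounds named here, the only step between measured compounds that differ in one place, a step that the two limits leave unreadable from compound 2 to compound 3, joins two limits and so its size cannot be read. Thus compound 3 stands at the limit of > 100 nM in this assay, at which 2 of the 3 values shown sit, with nothing in this set that places it more precisely.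

Compound 4 `CC#CCn1c(N2CCC[C@@H](N)C2)cc(=O)n(Cc2cc(C(=O)O)ccc2F)c1=O` differs from compound 3 by 5-carboxy-2-fluorophenyl in place of 3-carboxy-4-fluorophenyl on a saturated chain carbon bound to an aromatic nitrogen. Going by the values given here, no measured step bears on this change, since both values that could frame it are limits. The expected outcome for compound 4 is therefore another limit or a weak value, estimated at 300 nM, ranging from 100 nM to 3000 nM. The step that the limit leaves unreadable from compound 3 to compound 4 is expected to be small and unreadable against the limit.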

Compound 4, half-maximal inhibitory concentration: > 100 nM
Compound 4: no number, only a limit (the forecaster's own chance of this, stated with the estimate: 70%); the middle value is on the limit's open side.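

In this assay compound 4 gives > 100 nM, which is a limit and not a number. For the compounds shown here, the change from compound 3 to compound 4 therefore gives no step that can be read. The compounds shown leave open how strongly each one inhibits the enzyme, and the values offer no ranking: the limit of > 100 nM in this assay, at which 3 of the 4 values shown sit.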